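Benzyl carbonate in place of benzyl carbamate on the shared core

The source may report more compounds than this note shows. Statements on the series, on what has been measured and on what is new or still open speak of the compounds shown alone.

Compound 1 `Nc1ncnc2c1ncn2[C@@H]1O[C@H](COC(=O)NCc2ccccc2)[C@@H](O)[C@H]1O` carries a benzylamino carbonyl on the shared core. In an assay on COS-7 cells for inhibition of sodium/nucleoside cotransporter 2 (Homo sapiens), read by scintillation counting, in the presence of a further agent that is not named here (a higher number here means a weaker inhibitor, a lower number a stronger inhibitor), compound 1 gives > 100000 nM, which is a limit of the assay and not a number, so compound 1 stands only at the limit of > 100000 nM in this assay, at which 1 of the 3 values shown sits. The two remaining compounds carry their substituent elsewhere: compound 2 `Nc1ncnc2c1nc(NCc1ccc3ccccc3c1)n2[C@@H]1O[C@H](CO)[C@@H](O)[C@H]1O` gives 5300 nM in this assay, and compound 3 `Nc1ncnc2c1nc(NCCCc1ccccc1)n2[C@@H]1O[C@H](CO)[C@@H](O)[C@H]1O` gives 536000 nM. Going by the values given here, the one measured step, a 100-fold higher number from compound 2 to compound 3 (2.00 log units; beyond the scatter), concerns a different part of the molecule and does not bear on the change considered here. Compound 4 `Nc1ncnc2c1ncn2[C@@H]1O[C@H](COC(=O)OCc2ccccc2)[C@@H](O)[C@H]1O` differs from compound 1 by benzyloxy in place of benzylamino on a carbonyl carbon. Among the compounds with values here, no measured step covers this exchange; the only anchor is compound 1 itself at the limit. The expected step is a step that the limit leaves unreadable from compound 1 to compound 4, none beyond the scatter, with compound 4 expected to remain at the limit. Compound 4 is estimated at 200000 nM, within 100000 nM to 1000000 nM, and a limit rather than a number is the likely report.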

Compound 4, half-maximal inhibitory concentration: > 100000 nM
Compound 4 gave a limit, no number (the forecaster's own chance of this, stated with the estimate: 80%); the middle value is on the limit's open side.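

Compound 1 and compound 4 both give only a limit of the assay in this assay, so no step between them can be read: the limit of > 100000 nM in this assay, at which 2 of the 4 values shown sit.

The compounds shown leave open whether benzyloxy in place of benzylamino on a carbonyl carbon changes inhibition at all.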